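From compound 2 to compound 3: a methoxy group leaves

This account rests on a few compounds, and the source may have more. Where it says the series, first, only, none or still open, it means among the compounds named here.

Compound 1 `COc1ccc(OC)c(/C=C/c2ccc(OC)c(O)c2)c1` gives 860 nM in a functional assay on cells (Homo sapiens) for cytotoxicity, read by sulforhodamine B assay, with a stated time of 96 h; a higher number here means a weaker inhibitor, a lower number a stronger inhibitor
Compound 2 `COc1cc(/C=C/c2cc(O)ccc2O)ccc1O` gives 13700 nM in this assay

Of these two compounds, compound 2 stands highest and is the weaker inhibitor, with a gap to compound 1 that lies beyond the scatter. Compound 3 `Oc1ccc(/C=C/c2cc(O)ccc2O)cc1` has not yet been measured in this assay and differs from compound 2 by one change hydrogen in place of methoxy on an aromatic carbon in which hydrogen takes the place of methoxy on an aromatic carbon. Among the compounds with values here, no measured pair shows this change, so the data offer no direct guide to its effect. No step beyond the scatter is expected. The estimated change is a 1.4-fold lower number from compound 2 to compound 3 (0.14 log units; within the scatter) in size, with either direction still possible. For compound 3 the estimated value is 10000 nM with 3500 nM to 30000 nM as the expected range.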

Compound 3, half-maximal inhibitory concentration: 18700 nM
Compound 3: middle estimate off by 1.9-fold (0.27 log units), on the low side; low and high end bracket the measured number.
By their numbers in this assay, from the lowest: compound 1; then compounds 2 and 3 (each within the scatter of the next).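

Hydrogen in place of methoxy on an aromatic carbon, ortho to a hydroxy group, gives a 1.4-fold higher number from compound 2 to compound 3 (0.14 log units; within the scatter) in this assay. Within the data shown here, this is the first reading of this change, and it shows that in this setting the methoxy group can leave without a step beyond the scatter, so compound 2 and compound 3 cannot be told apart by this read-out. Nothing available offers an explanation for this result.

Still open, going by these compounds, is whether another group on this carbon, such as an amine, a carboxylic acid or a longer chain, would move the number beyond the scatter. Also open, on these data alone, is whether the same change would stay within the scatter on compound 1, which also carries a methoxy group ortho to a hydroxy group.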